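The source may hold more compounds than are shown below. What is called first, only, known or untested is meant among the compounds shown, and "the series" means these compounds.

Compound 1 `NS(=O)(=O)OC[C@@H]1C[C@@H](n2nnc3c(NCc4ccccc4F)ncnc32)C[C@@H]1O` and compound 2 `NS(=O)(=O)OC[C@@H]1C[C@@H](n2nnc3c(N[C@@H]4c5ccccc5C[C@@H]4O)ncnc32)C[C@@H]1O` share one core and differ only in the group carried on a nitrogen on an aromatic ring. In an assay on a protein complex for inhibition of NEDD8 activating enzyme (Homo sapiens), read by HTRF, with a stated time of 2 h, in the presence of a further agent that is not named here (on this read-out higher numbers stand for weaker inhibition and lower numbers for stronger inhibition), compound 1 gives 6.11 nM, while compound 2 gives 2.28 nM, so that the step is a 2.7-fold lower number from compound 1 to compound 2 (0.43 log units; beyond the scatter). Compound 2 thus holds the lowest number of the two that have been measured. Compound 3 `COCC(=O)N[C@H]1Cc2ccccc2[C@H]1Nc1ncnc2c1nnn2[C@@H]1C[C@@H](COS(N)(=O)=O)[C@@H](O)C1` keeps the group that entered in compound 2 and is altered elsewhere: ((methoxymethyl)carbonyl)amino in place of hydroxy on a saturated ring carbon. For the measured compounds named here, no measured step concerns this place: the single step between compound 1 and compound 2 changes a different part of the molecule, so it offers no direct guide to the effect here. With nothing comparable to lean on, a modest shift in either direction is considered plausible, and the estimate for compound 3 is 4 nM, within a range from 1.5 nM to 12 nM. The expected step is a 1.8-fold higher number from compound 2 to compound 3 (0.24 log units; within the scatter).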

Compound 3, half-maximal inhibitory concentration: 170 nM
Compound 3: middle estimate off by 43-fold (1.63 log units), on the low side, outside the stated range (above it).
By their numbers in this assay, from the lowest: compound 2; then compound 1; then compound 3.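

At this saturated ring carbon, ((methoxymethyl)carbonyl)amino in place of hydroxy gives a 75-fold higher number from compound 2 to compound 3 (1.87 log units; beyond the scatter) in this assay, so the number depends strongly on what this place carries, which the earlier step at the nitrogen could not show. The large step comes although both groups have no net charge and the same count of hydrogen-bond donors, so neither of these two counts separates them. What the entering group adds is more heavy atoms, a further hydrogen-bond acceptor and a double bond outside aromatic rings, and nothing measured here tells which of these matters, if any. The compounds shown leave open whether the step follows the whole chain or only a part of it. A free amine, a simple acetylamino group or a methoxy group at this carbon would begin to separate these cases.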